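Cytotoxicity notes: methylsulfanyl in place of pentyloxy

The source may hold more compounds than are shown below. What is called first, only, known or untested is meant among the compounds shown, and "the series" means these compounds.

Compound 1 `CCCCCOc1nc(N)nc2c1ncn2/C=C1/CC1(CO)CO` stands only at a limit on the numbers shown. In an ADME assay on CCRF-HSB-2 cells (Homo sapiens) for cytotoxicity, with a stated time of 7 days (a lower number here means that less compound is tolerated, a higher number that more compound is tolerated), compound 1 gives > 20000 nM, which is a limit of the assay and not a number. In this assay compound 2 `Nc1nc2c(ncn2/C=C2/CC2(CO)CO)c(=O)[nH]1` gives > 20000 nM, again a limit. In this assay compound 3 `COCCOc1nc(N)nc2c1ncn2/C=C1/CC1(CO)CO` gives > 20000 nM, also a limit. Among the measured compounds shown here, the single change between measured compounds, a step that the two limits leave unreadable from compound 1 to compound 3, is left unreadable, since all three values sit at the limit of > 20000 nM in this assay, at which 3 of the 3 values shown sit. Compound 4 `CSc1nc(N)nc2c1ncn2/C=C1/CC1(CO)CO` differs from compound 1 by methylsulfanyl in place of pentyloxy on an aromatic carbon. For the measured compounds named here, no measured step bears on this change, and no step beyond the scatter is expected in this assay. Compound 4 is estimated at 30000 nM, between 15000 nM and 100000 nM. The step this estimate means, a step that the limit leaves unreadable from compound 1 to compound 4, is expected to lie within the scatter.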

Compound 4, half-maximal cytotoxic concentration: > 100000 nM
Compound 4: only a limit was reported (the forecaster's own chance of this, stated with the estimate: 85%); middle value at least 3.3-fold (0.52 log units) away from the limit.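

In this assay compound 4 gives > 100000 nM, a limit of the assay and not a number, and its steps from compound 1 and compound 3 cannot be read. The compounds shown leave open at what concentration any of them becomes cytotoxic, and whether methylsulfanyl, pentyloxy and 2-methoxyethoxy differ at all.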